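The source may hold more compounds than are shown below. What is called first, only, known or untested is meant among the compounds shown, and "the series" means these compounds.

From the compounds shown here alone, in a functional assay on L1210 cells (Mus musculus) for inhibition (on this read-out higher numbers stand for weaker inhibition and lower numbers for stronger inhibition), compound 1 `C#CCN(Cc1ccc2nc(C)nc(O)c2c1)c1cccc(C(F)(F)F)c1` is reported only as a limit, > 2200 nM, so its exact place is unknown. The bromo analogue, compound 2 `C#CCN(Cc1ccc2nc(C)nc(O)c2c1)c1cccc(Br)c1`, gives a number, 1800 nM. Going by the values given here, the only measured step is an at least 1.2-fold lower number from compound 1 to compound 2 (0.08 log units; that floor lies within the scatter), with bromo in place of trifluoromethyl on an aromatic carbon.

Compound 3 `C#CCN(Cc1ccc2nc(C)nc(S)c2c1)c1cccc(C(F)(F)F)c1` keeps the trifluoromethyl group of compound 1 and changes the shared core instead: sulfanyl in place of hydroxy on an aromatic carbon, next to the ring nitrogen. The measured step lies at a different place in the molecule, so it does not test this change directly and shows only the general level of the two compounds. Among the compounds with values here, with no measured step at this place, no change beyond the scatter is expected in this assay, in either direction, and a result reported only as a limit would not be a surprise.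

The expected step is a step that the limit leaves unreadable from compound 1 to compound 3. For compound 3 the estimated value is 2500 nM, with an expected range of 900 nM to 7000 nM.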

Compound 3, half-maximal inhibitory concentration: > 5600 nM
Compound 3 gave a limit, no number; the forecaster's own chance of this, stated with the estimate: 45%; middle value at least 2.2-fold (0.35 log units) from the limit.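

The step from compound 1 to compound 3, sulfanyl in place of hydroxy on an aromatic carbon, cannot be read, as both compounds stand only as limits in this assay. The compounds shown leave open whether this exchange changes inhibition in this assay at all, and if it does, in which direction and by how much.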